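The compounds below may be only part of what the source reports. "The series", "measured", "known", "first", "only" and "open" are said of these compounds alone.

Measured so far:
compound 1 `COc1cc(Br)ccc1Nc1cc(NC(=O)Nc2c(Cl)cccc2Cl)ncn1` gives 43%
compound 2 `COc1cc(NC(=O)Nc2cc(Nc3ccc(F)c(Cl)c3)ncn2)cc(OC)c1` gives 36.7%
compound 3 `COc1cc(NC(=O)Nc2cc(Nc3ccc(Br)cc3OC)ncn2)cc(OC)c1` gives 25.7%

In a functional assay on NCI-H226 cells (Homo sapiens) for inhibition, read by MTT assay, with a stated time of 48 h, tested at 10 uM (a higher number here means more inhibition at the concentration tested (going by the name of the read-out), a lower number less inhibition), compound 1 gives the highest of the three numbers. Compound 2 comes nearest, within the usual scatter of compound 1, so no order between these two is claimed. Compound 3 sits furthest away: a number 17.3 percentage points lower from compound 1 to compound 3 (beyond the scatter), a change of 3,5-dimethoxyphenyl in place of 2,6-dichlorophenyl on an amide-type nitrogen.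

Compound 4 `COc1ccc(Nc2cc(NC(=O)Nc3c(Cl)cccc3Cl)ncn2)cc1C` is not yet measured. It differs from compound 1 as follows: 4-methoxy-3-methylphenyl in place of 4-bromo-2-methoxyphenyl on a nitrogen on an aromatic ring.

Among the measured compounds shown here, the one measured step that bears on this place is the one between compound 2 and compound 3, where a group on a nitrogen on an aromatic ring was exchanged: a number 11 percentage points lower from compound 2 to compound 3 (beyond the scatter). For the measured compounds named here, that step is modest, and it runs on a different pairing of groups than the one in compound 4, so it gives only a loose guide. In compound 4 the 2,6-dichlorophenyl on the amide-type nitrogen, which accompanies the highest number in compound 1, is kept.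

Compound 4 is therefore expected to land close to compound 1 in this assay, with the step of a number 3 percentage points lower from compound 1 to compound 4 (within the scatter) not clearly beyond the scatter in either direction. The estimate for compound 4 is 40%, with a range from 22% to 58%.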

Compound 4, a percentage reported as inhibition, at one concentration (the size of the read-out at that concentration, not a potency): 50%
For compound 4 the middle estimate is 10 percentage points below the measured one; low and high end bracket the measured number.
By their numbers in this assay, from the lowest: compound 3; then compounds 2, 1 and 4 (each within the scatter of the next, the first and the last beyond it).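

In this assay, placing 4-methoxy-3-methylphenyl where 4-bromo-2-methoxyphenyl stood on a nitrogen on an aromatic ring, with the 2,6-dichlorophenyl kept, gives a number 7 percentage points higher from compound 1 to compound 4 (within the scatter) and so does not separate the two groups. The earlier change at this place, made with 3,5-dimethoxyphenyl on the amide-type nitrogen, gave a number 11 percentage points lower from compound 2 to compound 3 (beyond the scatter) and had shown only that a swap there could matter. Compound 4 carries no bromine, so with 2,6-dichlorophenyl on the amide-type nitrogen, a number of this size does not depend on that atom, and nothing shown here gives a reason for the result.

As far as these compounds go, whether 4-methoxy-3-methylphenyl would do the same alongside 3,5-dimethoxyphenyl remains open. So does the outcome of replacing the aromatic group at this place with a simple alkyl amine chain, or of adding a carboxylic acid to it.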